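The source may report more compounds than this note shows. Statements on the series, on what has been measured and on what is new or still open speak of the compounds shown alone.

Compound 1 `C[S+]([O-])/C=C/c1cc(=O)c2cc(C#N)ccc2o1`: > 10000 nM
Compound 2 `CC(C)Oc1ccc2oc(/C=C/[S+](C)[O-])cc(=O)c2c1`: 1500 nM

Among the measured compounds shown here, in a functional assay on A549 cells (Homo sapiens) for cytotoxicity, with a stated time of 48 h (on this read-out higher numbers stand for weaker inhibition and lower numbers for stronger inhibition), compound 2 gives 1500 nM, the only actual number so far. The > 10000 nM of compound 1 is a limit of the assay, not a number.

Compound 3 `C[S+]([O-])/C=C/c1cc(=O)c2cc(OC(=O)C(C)(C)C)ccc2o1` has (tert-butyl)carbonyl in place of isopropyl on an oxygen on an aromatic ring. For the measured compounds named here, the only measured step, an at least 6.6-fold lower number from compound 1 to compound 2 (0.82 log units; beyond the scatter), replaced cyano with isopropoxy, a different change that starts from a limit. It offers only weak guidance, so a small rise in the number, within the scatter, is expected: a 1.3-fold higher number from compound 2 to compound 3 (0.12 log units; within the scatter). For compound 3 the estimated value is 2000 nM, with an expected range of 700 nM to 8000 nM.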

Compound 3, half-maximal inhibitory concentration: 1600 nM
Beside the measured number, compound 3's estimate is 1.3-fold (0.10 log units) above it; the range from low to high includes it.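

On the oxygen on an aromatic ring, (tert-butyl)carbonyl in place of isopropyl gives a 1.1-fold higher number from compound 2 to compound 3 (0.03 log units; within the scatter) in this assay, so the added carbonyl and its hydrogen-bond acceptor leave the read-out within the scatter. With ((tert-butyl)carbonyl)oxy in place of cyano on an aromatic carbon, the result is an at least 6.2-fold lower number from compound 1 to compound 3 (0.79 log units; beyond the scatter), making this the second oxygen-linked group to stand beyond the scatter from cyano. The value of compound 1 is a limit of the assay, not a number: the limit of > 10000 nM in this assay, at which 1 of the 3 values shown sits.

As far as these compounds go, whether an amine or a carboxylic acid on this aromatic carbon would give a lower number remains open. So does the effect of a longer chain on the oxygen.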